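The source may hold more compounds than are shown below. What is called first, only, known or untested is meant among the compounds shown, and "the series" means these compounds.

Measured so far:
Compound 1 (`COc1ccc(-c2cc(C(O)(C(F)(F)F)C(F)(F)F)cnc2N2CCN(S(=O)(=O)c3ccc(N)nc3)CC2)cn1`) gives 25 mL.min-1.g-1
Compound 2 (`Nc1ccc(S(=O)(=O)N2CCN(c3ncc(C(O)(C(F)(F)F)C(F)(F)F)cc3-c3cc4ccccc4[nH]3)CC2)cn1`) gives < 14 mL.min-1.g-1 (a limit)

In an ADME assay (liver) for metabolic stability, with Liver microsome (Homo sapiens) as the target, using microsomes and NADPH, with a stated time of 30 min, tested at 1 uM (a lower number here means slower removal, a higher number faster removal of the compound), compound 2 gives < 14 mL.min-1.g-1, which is a limit of the assay and not a number. Compound 2 therefore stands at the limit of < 14 mL.min-1.g-1 in this assay, at which 1 of the 2 values shown sits.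

Compound 3 (`Nc1ccc(S(=O)(=O)N2CCN(c3ncc(C(O)(C(F)(F)F)C(F)(F)F)cc3-c3cc4ccccc4s3)CC2)cn1`) carries 1-benzothiophen-2-yl in place of 1H-indol-2-yl on an aromatic carbon.

Among the compounds with values here, only one measured step touches this same aromatic carbon, and it exchanged a different pair of groups. That step is an at least 1.7-fold lower number from compound 1 to compound 2 (0.25 log units; that floor lies within the scatter), and its floor lies within the scatter. It gives no firm guide to direction, so no step beyond the scatter is expected here.

The expected change is an at least 1.1-fold higher number from compound 2 to compound 3 (0.05 log units; that floor lies within the scatter).

For compound 3 the estimate is 16 mL.min-1.g-1, with an expected range from 8 mL.min-1.g-1 to 32 mL.min-1.g-1.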

Compound 3, intrinsic clearance in microsomes: < 14 mL.min-1.g-1
Compound 3: only a limit was reported (the forecaster's own chance of this, stated with the estimate: 45%); middle value at least 1.1-fold (0.05 log units) from the limit.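

In this assay compound 3 gives a limit of the assay and not a number, the same limit as compound 2: the limit of < 14 mL.min-1.g-1 in this assay, at which 2 of the 3 values shown sit. The step between compound 2 and compound 3 cannot be read, so the exchange of 1H-indol-2-yl, which carries a hydrogen-bond donor, for 1-benzothiophen-2-yl, which carries none, has no measurable size here. Putting 1-benzothiophen-2-yl in place of 6-methoxypyridin-3-yl gives an at least 1.7-fold lower number from compound 1 to compound 3 (0.25 log units; that floor lies within the scatter), so a second group built from a five-membered and a six-membered aromatic ring reads as the first did, though that floor does not establish a real change.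

On these data alone, how far the true values of compound 2 and compound 3 lie past the limit stays open. Also open, as far as these compounds go, is whether a plain phenyl ring or a small amine on this aromatic carbon would give a readable value.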